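Aryl swap on the saturated ring carbon: toward compound 3

A few compounds are considered here, and "the series" means these few. Any claim that something is new, unique, unknown or untested is made for them only; others in the source may bear on it.

Measured so far:
compound 1 `COc1ccc(C2C(C#N)=C(N)N(c3cc(OC)c(OC)c(OC)c3)C3=C2C(=O)CC(C)(C)C3)cc1`: 15%
compound 2 `COc1cc(N2C(N)=C(C#N)C(c3ccc(OC)c4ccccc34)C3=C2CC(C)(C)CC3=O)cc(OC)c1OC`: 40%

In a functional assay on Ehrlich cells (Mus musculus) for cytotoxicity, tested at 100 ug/mL (a lower number here means a weaker effect, a higher number a stronger effect of the compound at the concentration tested), compound 1 gives 15% and compound 2 gives 40%. Compound 2 stands highest of the two numbers; the nearest is compound 1, which lies lower by a step beyond the scatter. That step, a number 25 percentage points higher from compound 1 to compound 2 (beyond the scatter), accompanied the exchange of 4-methoxyphenyl for 4-methoxynaphthalen-1-yl on a saturated ring carbon.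

Compound 3 `COc1ccccc1C1C(C#N)=C(N)N(c2cc(OC)c(OC)c(OC)c2)C2=C1C(=O)CC(C)(C)C2` is not yet measured in this assay. It differs from compound 2 at that same position: 2-methoxyphenyl in place of 4-methoxynaphthalen-1-yl on a saturated ring carbon. Going by the values given here, the only measured step that bears on this change is a number 25 percentage points higher from compound 1 to compound 2 (beyond the scatter), in which the second aromatic ring entered; in compound 3 that second ring leaves again. Among the compounds with values here, the entering 2-methoxyphenyl is not the same group as the 4-methoxyphenyl of compound 1, so compound 1 is only a partial guide, and the series gives no step for a 2-methoxyphenyl on its own.

On this basis a downward step is expected, roughly undoing the earlier rise: the expected step is a number 20 percentage points lower from compound 2 to compound 3 (beyond the scatter). Compound 3 is therefore estimated at 20%, with a range from 5% to 40%.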

Compound 3, a percentage reported as activity, at one concentration (the size of the read-out at that concentration, not a potency): 100%
Estimate against measurement, compound 3: 80 percentage points below; measured number outside the range, above it.
By their numbers in this assay, from the lowest: compound 1; then compound 2; then compound 3.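

In this assay, the group on the saturated ring carbon carries far more weight than the first step showed: a number 85 percentage points higher from compound 1 to compound 3 (beyond the scatter), with 2-methoxyphenyl in place of 4-methoxyphenyl, two groups whose names differ only in the number that places the methoxy group. The second aromatic ring of 4-methoxynaphthalen-1-yl is not required for a high read-out, as a number 60 percentage points higher from compound 2 to compound 3 (beyond the scatter), yet the count of aromatic rings alone does not order the three compounds, since compound 1 and compound 3 both have one such ring in this group and lie at opposite ends of the series. No measurement at hand accounts for either step.

Open, from the compounds shown here alone, is whether the high read-out belongs to the 2-methoxy arrangement specifically, which a plain phenyl, a 3-methoxyphenyl, a 2-hydroxyphenyl or a 2-chlorophenyl at this carbon would help to settle. Also open, going by these compounds, is how compound 3 behaves below the single tested concentration, and whether its advantage holds with a group other than 3,4,5-trimethoxyphenyl on the ring nitrogen, such as a plain phenyl or a benzyl group.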